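Chloro for fluoro on the aryl of compound 1

The compounds below may be only part of what the source reports. "The series", "measured", "known", "first", "only" and "open" are said of these compounds alone.

Compound 1 `COc1ccc(-c2csc(N3N=C(c4ccc(F)cc4)CC3c3ccc4c(c3)OCCO4)n2)cc1` gives 4530 nM in a functional assay on MCF7 cells (Homo sapiens) for antiproliferative activity, read by MTT assay, with a stated time of 48 h (a lower number here means a stronger inhibitor, a higher number a weaker inhibitor), the highest of the three numbers in hand, with compound 2 nearest and compound 3 furthest. Compound 2 `Fc1ccc(C2=NN(c3nc(-c4ccc(Br)cc4)cs3)C(c3ccc4c(c3)OCCO4)C2)cc1` gives 4200 nM, and compound 3 `Cc1ccc(C2=NN(c3nc(-c4ccc(Br)cc4)cs3)C(c3ccc4c(c3)OCCO4)C2)cc1` gives 1590 nM. The step of a 1.1-fold lower number from compound 1 to compound 2 (0.03 log units; within the scatter) stays within the scatter, whereas a 2.6-fold lower number from compound 2 to compound 3 (0.42 log units; beyond the scatter) is a modest gain. Compound 4 `COc1ccc(-c2csc(N3N=C(c4ccc(Cl)cc4)CC3c3ccc4c(c3)OCCO4)n2)cc1` differs from compound 1 by chloro in place of fluoro on an aromatic carbon. Only a 2.6-fold lower number from compound 2 to compound 3 (0.42 log units; beyond the scatter) also removes fluoro on an aromatic carbon, but it brings in methyl rather than chloro, so it bears on this step only loosely. Compound 4 is therefore expected to show a small step, a 1.3-fold lower number from compound 1 to compound 4 (0.11 log units; within the scatter), probably within the scatter. Compound 4 is estimated at 3500 nM, with a range of 1500 nM to 8000 nM.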

Compound 4, half-maximal inhibitory concentration: 3030 nM
For compound 4 the middle estimate is 1.2-fold (0.06 log units) above the measured one; the measured number falls inside the stated range.
By their numbers in this assay, from the lowest: compounds 3, 4, 2 and 1 (each within the scatter of the next, the first and the last beyond it).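

In this assay chloro in place of fluoro on this aryl ring gives a 1.5-fold lower number from compound 1 to compound 4 (0.17 log units; within the scatter) and so leaves no readable change at this position. The only other change shown here, methyl in place of fluoro, gives a 2.6-fold lower number from compound 2 to compound 3 (0.42 log units; beyond the scatter) on the bromo-substituted compounds, so this position is not silent to every replacement of fluoro. Nothing available accounts for either step.

As far as these compounds go, an amine or a carboxylic acid at this position remains open. Also open, from the compounds shown here alone, is whether chloro in place of fluoro reads the same in the bromo-substituted compounds.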